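This account rests on a few compounds, and the source may have more. Where it says the series, first, only, none or still open, it means among the compounds named here.

Working notes on the series, followed in a functional assay on CHO cells for antagonist activity at prostaglandin E2 receptor EP3 subtype (Homo sapiens), read by cAMP accumulation; a lower number here means a stronger inhibitor, a higher number a weaker inhibitor.

Going by the values given here, compound 1 `CC(C)NC(=O)CC(c1ccc(-c2ccc3cccc(F)c3c2)[nH]c1=O)C(C)C` gives 15 nM and stands lowest of the three numbers measured so far. Among the compounds with values here, compound 2 `CC(C)C(CC(N)=O)c1ccc(-c2ccc3cccc(F)c3c2)[nH]c1=O` gives 53 nM; the step of a 3.5-fold higher number from compound 1 to compound 2 (0.55 log units; beyond the scatter) is the only single-point change measured, and it goes to a higher number. Compound 3 `CC(C)C(O)(C(=O)O)c1ccc(-c2ccc3ccccc3c2)[nH]c1=O` gives 1580 nM, the highest number of the three; it differs from compound 1 in more than one place, so only the two values themselves can be compared.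

Compound 4 `Cc1c[nH]c(C(c2ccc(-c3ccc4cccc(F)c4c3)[nH]c2=O)C(C)C)n1` is not yet measured. It differs from compound 1 in one place: 4-methyl-1H-imidazol-2-yl in place of (isopropylcarbamoyl)methyl on a saturated chain carbon bound to an aromatic carbon and a saturated chain carbon. The change in compound 2 bears on it only partly, since in compound 2 the amide-type chain is kept and only its substituent is removed, whereas in compound 4 the whole (isopropylcarbamoyl)methyl chain is gone and a 4-methyl-1H-imidazol-2-yl ring takes its place, keeping one hydrogen-bond donor and one hydrogen-bond acceptor. Within the data shown here, no measured step covers such an exchange. The loss of the isopropyl alone already cost a 3.5-fold higher number from compound 1 to compound 2 (0.55 log units; beyond the scatter), so a step of similar or somewhat larger size toward a higher number is expected, with wide uncertainty in both directions.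

For compound 4 the expected step is a 4.0-fold higher number from compound 1 to compound 4 (0.60 log units; beyond the scatter). The estimate for compound 4 in this assay is 60 nM, within a range from 15 nM to 300 nM.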

Compound 4, half-maximal inhibitory concentration: 36 nM
The estimate for compound 4 lay 1.7-fold (0.22 log units) above the measured number, within the range that was stated.
By their numbers in this assay, from the lowest: compound 1; then compounds 4 and 2 (each within the scatter of the next); then compound 3.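

At the saturated chain carbon bound to an aromatic carbon and a saturated chain carbon, the open (isopropylcarbamoyl)methyl chain can give way to a ring: in this assay, the exchange for 4-methyl-1H-imidazol-2-yl gives a 2.4-fold higher number from compound 1 to compound 4 (0.38 log units; beyond the scatter), so this position tolerates a five-membered aromatic ring with no carbonyl, at a modest cost. Measured against the carbamoylmethyl chain, the same ring gives a 1.5-fold lower number from compound 2 to compound 4 (0.17 log units; within the scatter), so in this assay the ring and that shorter amide chain cannot be told apart, while the isopropyl-capped chain of compound 1 keeps its lead over both. No measurement at hand accounts for these differences.

Still open is what the 4-methyl contributes, since the series shown offers no plain 1H-imidazol-2-yl or other ring at this carbon for comparison, such as a 1,2,4-triazolyl or a pyridyl. Also open, from the compounds shown here alone, is whether a longer chain, such as (tert-butylcarbamoyl)methyl, or a basic aminomethyl group at the same carbon would stay near compound 1 or fall away from it in this assay, as the present compounds cover only amide chains and one substituted imidazole here.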